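Side-chain terminus on the shared core: imidazolyl to methylpiperazinylmethyl

The compounds below may be only part of what the source reports. "The series", "measured", "known", "first", "only" and "open" are said of these compounds alone.

Measured so far:
compound 1 `CN(C)CCCCCn1c2c(c3ccccc31)C(=O)c1c[n+]([O-])c3ccccc3c1C2=O`, 470 nM
compound 2 `O=C1c2c[n+]([O-])c3ccccc3c2C(=O)c2c1c1ccccc1n2CCCCn1ccnc1`, 240 nM
compound 3 `O=C1c2c[n+]([O-])c3ccccc3c2C(=O)c2c1c1ccccc1n2Cc1cn(CC(O)CO)nn1`, 250 nM

All three share one core and differ only in the chain on the aromatic nitrogen. In a functional assay on HCT-116 cells (Homo sapiens) for cytotoxicity, read by MTT assay, with a stated time of 72 h (a lower number here means a stronger inhibitor, a higher number a weaker inhibitor), compound 2 gives the lowest of the three numbers, but its gaps to the others are small: a 2.0-fold lower number from compound 1 to compound 2 (0.29 log units; within the scatter) and a 1.0-fold higher number from compound 2 to compound 3 (0.02 log units; within the scatter), both within the scatter, as is a 1.9-fold lower number from compound 1 to compound 3 (0.27 log units; within the scatter). Changing the chain terminus has so far moved nothing beyond the scatter.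

Compound 4 `CN1CCN(CCCCCn2c3c(c4ccccc42)C(=O)c2c[n+]([O-])c4ccccc4c2C3=O)CC1` is the next step from compound 2. The change: (4-methylpiperazin-1-yl)methyl in place of 1H-imidazol-1-yl on a saturated chain carbon, four bonds along the chain from an aromatic nitrogen

The bearing steps are those at the same chain position, above all the step from compound 1 to compound 2, which swapped a (dimethylamino)methyl for the imidazolyl and stayed within the scatter. Compound 4 restores a tertiary amine at that end, close in kind to compound 1. The expected step of a 1.3-fold higher number from compound 2 to compound 4 (0.12 log units; within the scatter) is therefore small, in either direction, not beyond the scatter. Compound 4 is estimated at 320 nM, range 150 nM to 700 nM.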

Compound 4, half-maximal inhibitory concentration: 1220 nM
Estimate against measurement, compound 4: 3.8-fold (0.58 log units) below, outside the stated range (above it).
By their numbers in this assay, from the lowest: compounds 2, 3 and 1 (each within the scatter of the next); then compound 4.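

At this chain position, the terminus does matter in this assay: (4-methylpiperazin-1-yl)methyl in place of 1H-imidazol-1-yl gives the first step from this end of the chain that lies beyond the scatter (a 5.1-fold higher number from compound 2 to compound 4 (0.71 log units; beyond the scatter)). The two tertiary amines also separate, since 4-methylpiperazin-1-yl in place of dimethylamino gives a step beyond the scatter (a 2.6-fold higher number from compound 1 to compound 4 (0.41 log units; beyond the scatter)), and the triazolyl chain comparison points the same way (a 4.9-fold higher number from compound 3 to compound 4 (0.69 log units; beyond the scatter)), leaving compound 4 the weakest of the four. Nothing available gives a reason for these steps.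

Still open, from the compounds shown here alone, is whether the six-membered ring itself or its methylated nitrogen carries the step, which a piperidin-1-yl, morpholin-4-yl or unsubstituted piperazin-1-yl terminus on the same chain would separate. A shorter chain bearing 4-methylpiperazin-1-yl would test how far the step depends on chain length.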